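This account rests on a few compounds, and the source may have more. Where it says the series, first, only, none or still open, it means among the compounds named here.

Working notes on the series in a functional assay on L1210 cells (Mus musculus) for inhibition; on this read-out lower numbers stand for stronger inhibition and higher numbers for weaker inhibition. Going by the values given here, compound 3 `CC(=O)CC1C[C@@H](CCCCCCCC#C[C@@H](O)COCCOC[C@@H](O)N2CCCCC2)OC1=O` gives 28700 nM, the higher of the two exact numbers so far. Compound 2 `CC(=O)CC1C[C@@H](CCCCCCCC#C[C@@H](O)COCCOC[C@@H](O)c2ccc(C(F)(F)F)cc2)OC1=O` gives 3300 nM. Compound 1 `COc1ccc([C@H](O)COCCOC[C@H](O)C#CCCCCCCC[C@@H]2CC(CC(C)=O)C(=O)O2)cc1` is reported only as a limit of the assay, > 10000 nM.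

The next step leads to compound 4 `CC(=O)CC1C[C@@H](CCCCCCCC#C[C@@H](O)COCCOC[C@@H](O)c2ccc3ccccc3c2)OC1=O`: naphthalen-2-yl in place of piperidin-1-yl on a saturated chain carbon bound to an oxygen on a saturated carbon and a saturated chain carbon. In words, naphthalen-2-yl stands in place of piperidin-1-yl on a saturated chain carbon bound to an oxygen on a saturated carbon and a saturated chain carbon.

The nearest measured step is an 8.7-fold higher number from compound 2 to compound 3 (0.94 log units; beyond the scatter), where piperidin-1-yl replaces 4-(trifluoromethyl)phenyl. The step now in question runs the other way, from piperidin-1-yl back to an aromatic group, so a lower number is the expected direction. The aromatic groups also differ among themselves, an at least 3.0-fold lower number from compound 1 to compound 2 (0.48 log units; beyond the scatter), so an aromatic group alone does not settle the number. The remaining measured step, a step that the limit leaves unreadable from compound 1 to compound 3, gives no size.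

A modest fall is therefore expected, somewhat smaller than the full distance separating the two exact values. The expected step is a 5.2-fold lower number from compound 3 to compound 4 (0.72 log units; beyond the scatter). For compound 4 the estimated value is 5500 nM, with an expected range of 1800 nM to 17000 nM.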

Compound 4, half-maximal inhibitory concentration: 2100 nM
The estimate for compound 4 lay 2.6-fold (0.42 log units) above the measured number, and the stated range covers the measured number.
By their numbers in this assay, from the lowest: compounds 4 and 2 (each within the scatter of the next); then compound 3.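

At this position in this assay, naphthalen-2-yl in place of piperidin-1-yl gives a 14-fold lower number from compound 3 to compound 4 (1.14 log units; beyond the scatter), so a lower number than with piperidin-1-yl now holds for two aromatic groups, in compounds 2 and 4, while compound 1 cannot be placed against compound 3 since that step is unreadable. Naphthalen-2-yl in place of 4-(trifluoromethyl)phenyl gives a 1.6-fold lower number from compound 2 to compound 4 (0.20 log units; within the scatter), so the second aromatic ring brings no readable change over the substituted phenyl group. Against 4-methoxyphenyl, the change gives an at least 4.7-fold lower number from compound 1 to compound 4 (0.67 log units; beyond the scatter), a step that rests on a limit of the assay and not on a number: the limit of > 10000 nM in this assay, at which 1 of the 4 values shown sits.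

As far as these compounds go, what stays open is whether the gap to piperidin-1-yl follows the aromatic ring or the ring nitrogen, a question that a cyclohexyl group at this position would address. Also open, from the compounds shown here alone, is how an unsubstituted phenyl group, or a phenyl group carrying a carboxylic acid, would read here, and so whether the 4-methoxy group on compound 1 or the aromatic ring beneath it governs the limit seen there.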